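Replacing Methoxymethoxy with Fluoro on the Shared Core

The source may hold more compounds than are shown below. What is called first, only, known or untested is meant among the compounds shown, and "the series" means these compounds.

Measured in a functional assay on MCF7 cells (Homo sapiens) for antiproliferative activity, with a stated time of 72 h; on this read-out higher numbers stand for weaker inhibition and lower numbers for stronger inhibition:
- Compound 1 `C=C1C=CC(=O)[C@@H]2[C@H](Cc3ccc(OCOC)cc3)CC[C@H]12` gives 63.6 nM
- Compound 2 `C=C1C=CC(=O)[C@@H]2[C@H](Cc3ccc(OCOC)c(F)c3)CC[C@H]12` gives 77.2 nM
- Compound 3 `C=C1C=CC(=O)[C@@H]2[C@H](Cc3cc(OC)c(OC)c(OC)c3)CC[C@H]12` gives > 1000 nM, which is a limit and not a number

Among the measured compounds shown here, compound 2, at 77.2 nM, stands within the scatter of compound 1, and these two are the only compounds with numbers. The next step leads to compound 4 `C=C1C=CC(=O)[C@@H]2[C@H](Cc3ccc(F)c(F)c3)CC[C@H]12` and puts fluoro in place of methoxymethoxy on an aromatic carbon. For the measured compounds named here, the only measured step, a 1.2-fold higher number from compound 1 to compound 2 (0.08 log units; within the scatter), is a different change, fluoro in place of hydrogen, so it offers little guidance. Going by the values given here, no measured step removes methoxymethoxy directly. Among the measured compounds, only compound 3 lacks that group, and it stands at the limit of > 1000 nM. A clear move towards a higher number is therefore expected in this assay, though its size is uncertain. The expected step is a 2.8-fold higher number from compound 2 to compound 4 (0.45 log units; beyond the scatter). For compound 4 the estimated value is 220 nM. The expected range runs from 60 nM to 1000 nM.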

Compound 4, half-maximal inhibitory concentration: 233 nM
Compound 4: middle estimate off by 1.1-fold (0.02 log units), on the low side, within the range that was stated.
By their numbers in this assay, from the lowest: compounds 1 and 2 (each within the scatter of the next); then compound 4. At a limit, above all of these: compound 3.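

Among the compounds shown here, exchanging methoxymethoxy for fluoro on the aromatic carbon ortho to a fluoro group gives, in this assay, a 3.0-fold higher number from compound 2 to compound 4 (0.48 log units; beyond the scatter), the first direct reading of what leaving this group does, and it is a modest move towards weaker inhibition beyond the scatter. The loss of methoxymethoxy does not end the activity at this position, as compound 4 still gives 233 nM. Compound 3 differs from compound 4 in more than one place and stays outside this comparison, its value being a limit and not a number: the limit of > 1000 nM in this assay, at which 1 of the 4 values shown sits.

The compounds shown do not separate the departure of methoxymethoxy from the arrival of fluoro, and they give no cause for the step. From the compounds shown here alone, how a hydroxyl group, an amine or a carboxylic acid would read at this position stays open.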